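The source may hold more compounds than are shown below. What is called first, only, known or untested is meant among the compounds shown, and "the series" means these compounds.

Measured compounds:
Compound 1, `Cc1ccc(CNc2ncnc3c2ncn3[C@@H]2O[C@H](CO)[C@@H](O)[C@H]2O)cc1`: in a functional assay on CCRF-CEM cells (Homo sapiens) for antiproliferative activity, with a stated time of 72 h (on this read-out lower numbers stand for stronger inhibition and higher numbers for weaker inhibition), compound 1 gives > 166000 nM, which is a limit of the assay rather than a number.
Compound 2, `OC[C@H]1O[C@@H](n2cnc3c(NCc4ccc(Cl)c(Cl)c4)ncnc32)[C@H](O)[C@@H]1O`: in this assay compound 2 gives 3800 nM.
Compound 3, `OC[C@H]1O[C@@H](n2cnc3c(NCc4cc(F)cc(F)c4)ncnc32)C(O)C1O`: in this assay compound 3 gives 24500 nM.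

Compound 1 stands at the weak end of what has been measured: its value is only a limit, the one at which (the limit of > 166000 nM in this assay, at which 1 of the 3 values shown sits). Compound 4, `OC[C@H]1O[C@@H](n2cnc3c(NCc4ccc(F)c(F)c4F)ncnc32)[C@H](O)[C@@H]1O`, has not yet been measured. It differs from compound 1 in one place: 2,3,4-trifluorophenyl in place of 4-methylphenyl on a saturated chain carbon bound to a nitrogen on an aromatic ring. For the measured compounds named here, the one measured step that bears on this change is an at least 43-fold lower number from compound 1 to compound 2 (1.64 log units; beyond the scatter), where a halogen-bearing phenyl likewise replaced the 4-methylphenyl at the same place and the number fell far below the limit. Going by the values given here, compound 3, another fluorine-bearing analogue, also gives a number well below that limit, although no single-point step to compound 1 is counted for it, and its number is higher than that of compound 2. A change to 2,3,4-trifluorophenyl is therefore expected to lower the number beyond the scatter, most likely to somewhere between the values of compound 2 and compound 3. For compound 4 the expected step is an at least 13-fold lower number from compound 1 to compound 4 (1.14 log units; beyond the scatter). The estimate for compound 4 is 12000 nM, with a range from 2500 nM to 60000 nM.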

Compound 4, half-maximal inhibitory concentration: 58200 nM
For compound 4 the middle estimate is 4.9-fold (0.69 log units) below the measured one; low and high end bracket the measured number.
By their numbers in this assay, from the lowest: compound 2; then compound 3; then compound 4. At a limit, above all of these: compound 1.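

The result shows that a halogen-bearing phenyl at this place, on a saturated chain carbon bound to a nitrogen on an aromatic ring, does not bring one fixed gain. Putting 2,3,4-trifluorophenyl in place of 4-methylphenyl gives an at least 2.8-fold lower number from compound 1 to compound 4 (0.45 log units; beyond the scatter), while putting it in place of 3,4-dichlorophenyl gives a 15-fold higher number from compound 2 to compound 4 (1.19 log units; beyond the scatter), so the choice among halogen-bearing phenyl groups itself matters a great deal here, which the earlier step from a methyl-bearing to a chlorine-bearing ring could not show. The first of these two steps can only be read as a minimum, since compound 1 gives a limit and not a number: the limit of > 166000 nM in this assay, at which 1 of the 4 values shown sits.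

The compounds shown do not separate the kind of halogen from the number and placement of the halogens, as compound 2 and compound 4 differ in all of these at once. They also leave open how the same place would respond to a phenyl carrying an amine or a carboxylic acid, or to a longer chain.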